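A few compounds are considered here, and "the series" means these few. Any claim that something is new, unique, unknown or untested is made for them only; others in the source may bear on it.

Compound 1 `N#Cc1c(N)nc(SCc2ccn[nH]2)c(C#N)c1-c1ccc(OCC2CC2)cc1` gives 84 nM in a functional assay on CHO cells for agonist activity at adenosine receptor A2b (Homo sapiens), read by AlphaScreen and cAMP accumulation; on this read-out higher numbers stand for an effect only at larger amounts of compound and lower numbers for an effect already at smaller amounts. Compound 2 `N#Cc1c(N)nc(SCC(=O)NCO)c(C#N)c1-c1ccc(OCC2CC2)cc1` gives 182 nM in this assay, and compound 3 `CCOc1ccc(-c2c(C#N)c(N)nc(SCC(N)=O)c2C#N)cc1` gives 38 nM. Compound 2 therefore carries the highest of the three numbers: its nearest neighbour is compound 1, and compound 3 lies furthest from it. Within the data shown here, the one recorded step leading into compound 2 is a 2.2-fold higher number from compound 1 to compound 2 (0.34 log units; beyond the scatter). Compound 4 `N#Cc1c(N)nc(SCc2ncc[nH]2)c(C#N)c1-c1ccc(OCC2CC2)cc1` has not yet been measured; it arises from compound 2 by 1H-imidazol-2-yl in place of (hydroxymethyl)carbamoyl on a saturated chain carbon bound to a sulfur. The step from compound 1 to compound 2 bears on this change, since the group that leaves compound 2 is the one that entered in that step, and what enters in compound 4 is again a five-membered aromatic ring, as in compound 1. Compound 3 differs from compound 2 in more than one place, so its lower value only marks the span of the series. On this basis compound 4 is expected to show a 2.1-fold lower number from compound 2 to compound 4 (0.33 log units; beyond the scatter), roughly reversing the step into compound 2. The estimate for compound 4 is 85 nM, with a range from 40 nM to 180 nM.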

Compound 4, half-maximal effective concentration: 9.5 nM
Compound 4: middle estimate off by 8.9-fold (0.95 log units), on the high side, and the stated range ends above it.
By their numbers in this assay, from the lowest: compound 4; then compound 3; then compound 1; then compound 2.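

Putting 1H-imidazol-2-yl in place of (hydroxymethyl)carbamoyl on a saturated chain carbon bound to a sulfur produced a 19-fold lower number from compound 2 to compound 4 (1.28 log units; beyond the scatter), a far larger change than a 2.2-fold higher number from compound 1 to compound 2 (0.34 log units; beyond the scatter). Among these compounds, the earlier compounds showed only that compound 1, with its five-membered aromatic ring, gave a lower number than compound 2, with its open-chain group. Compound 4 now shows that the identity of the ring matters at this place, since 1H-imidazol-2-yl in place of 1H-pyrazol-5-yl gives an 8.8-fold lower number from compound 1 to compound 4 (0.95 log units; beyond the scatter).

The compounds shown offer no measurement that explains the difference between these two rings. On these data alone, it remains open whether a 1,2,4-triazole, a methyl group on an imidazole ring nitrogen, or a longer chain between the sulfur and the imidazole would preserve the low number of compound 4.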